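Replacing isopropyl with 3-cyanophenyl on an amide-bearing ring

The compounds below may be only part of what the source reports. "The series", "measured", "known", "first", "only" and "open" are said of these compounds alone.

Of the compounds shown here, three sharing one core have been measured so far. Compound 1 `CC(C)(C)c1ccc(NC(=O)CCc2cccc3c2B(O)OC3)cc1` gives 4200 nM in a functional assay on SK-OV-3 cells (Homo sapiens) for antiproliferative activity, read by MTT assay, with a stated time of 72 h; on this read-out higher numbers stand for weaker inhibition and lower numbers for stronger inhibition. Compound 2 `COc1ccc(NC(=O)CCc2cccc3c2B(O)OC3)cc1` gives 900 nM. Compound 3 `CC(C)c1cccc(NC(=O)CCc2cccc3c2B(O)OC3)c1` gives 510 nM, the lowest of the three numbers, though its gap to compound 2 lies within the usual scatter, so the two cannot be ranked; its gap to compound 1 lies beyond the scatter.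

Compound 4 `N#Cc1cccc(-c2cccc(NC(=O)CCc3cccc4c3B(O)OC4)c2)c1` has not yet been measured. It differs from compound 3 in one place: 3-cyanophenyl in place of isopropyl on an aromatic carbon.

Among the measured compounds shown here, the only measured step, a 4.7-fold lower number from compound 1 to compound 2 (0.67 log units; beyond the scatter), concerns a different pair of groups at a similar location, so it bears on the new change only loosely. It does show that swapping a group on that ring can move the number by a modest amount in either direction. For the measured compounds named here, with no closer precedent, compound 4 is expected to give 1500 nM, within a range from 400 nM to 6000 nM. The step of a 2.9-fold higher number from compound 3 to compound 4 (0.47 log units; beyond the scatter) is thus estimated as a mild weakening, with considerable uncertainty.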

Compound 4, half-maximal inhibitory concentration: 120 nM
Compound 4: middle estimate off by 13-fold (1.10 log units), on the high side; measured number outside the range, below it.
By their numbers in this assay, from the lowest: compound 4; then compounds 3 and 2 (each within the scatter of the next); then compound 1.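

In this assay, the step of a 4.3-fold lower number from compound 3 to compound 4 (0.63 log units; beyond the scatter) shows that this aromatic carbon tolerates a much larger group than isopropyl, and that the number can fall rather than rise when one is added. Among the compounds shown here, none of the earlier compounds carries a second aromatic ring on the amide-bearing ring, so this is the first sign that such an extension can give stronger inhibition. Nothing at hand explains why 3-cyanophenyl gives the lower number.

The compounds shown do not separate the contribution of the added ring from that of its nitrile, a question that a plain phenyl group could help to settle. Nor do they show whether an amine or a carboxylic acid in place of the nitrile would keep the lower number.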